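The source may report more compounds than this note shows. Statements on the series, on what has been measured and on what is new or still open speak of the compounds shown alone.

Working notes on the series.

Of the compounds shown here, three carry numbers so far: compound 1 `C/C(=N\OCCSc1nnnn1C)c1ccc(Sc2cc(F)cc(C3CCOCC3)c2)cc1`, compound 2 `CS/C(=N\O)c1ccc(Sc2cc(F)cc(C3CCOCC3)c2)cc1` and compound 3 `C/C(=N\O)c1ccc(Sc2cc(F)cc(C3CCOCC3)c2)cc1`. In a functional assay (blood) for inhibition, with Homo sapiens as the target (a lower number here means a stronger inhibitor, a higher number a weaker inhibitor), compound 1 gives 120 nM, compound 2 gives 190 nM and compound 3 gives 80 nM. Compound 3 therefore holds the lowest of the three numbers, but the gap to compound 1 lies within the scatter, so the two cannot be ordered; only compound 2 stands apart, with a 2.4-fold lower number from compound 2 to compound 3 (0.38 log units; beyond the scatter).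

Compound 4 `C/C(=N\OCC#N)c1ccc(Sc2cc(F)cc(C3CCOCC3)c2)cc1` has not been measured in this assay. It differs from compound 3 in one place: cyanomethyl in place of hydrogen on an oxygen.

The step that bears on this change is the one at the same oxygen, a 1.5-fold lower number from compound 1 to compound 3 (0.18 log units; within the scatter), where a considerably larger group on that oxygen than the cyanomethyl of compound 4 made no difference beyond the scatter. The step from compound 2 to compound 3 concerns a different position and gives no guidance here. On that single precedent no shift beyond the scatter is expected, so the estimated step is a 1.3-fold higher number from compound 3 to compound 4 (0.10 log units; within the scatter). For compound 4 in this assay the expected value is 100 nM, with a range from 40 nM to 250 nM.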

Compound 4, half-maximal inhibitory concentration: 20 nM
Compound 4: the middle estimate sits 5.0-fold (0.70 log units) above what was measured, outside the stated range (below it).
By their numbers in this assay, from the lowest: compound 4; then compounds 3, 1 and 2 (each within the scatter of the next, the first and the last beyond it).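

In this assay, going by these compounds alone, the oxygen bound to the double-bonded nitrogen now proves sensitive to what it carries: cyanomethyl in place of hydrogen gives a 4.0-fold lower number from compound 3 to compound 4 (0.60 log units; beyond the scatter) and so moves the number beyond the scatter, which the one earlier change at this oxygen did not do. The two groups on that oxygen also separate from each other, with cyano in place of ((1-methyl-1H-tetrazol-5-yl)sulfanyl)methyl on a saturated chain carbon bound to an oxygen giving a 6.0-fold lower number from compound 1 to compound 4 (0.78 log units; beyond the scatter). The oxygen is therefore not indifferent to substitution, though this rests on compounds 1, 3 and 4 alone, and compound 1 still goes against any idea that substitution there lowers the number in general. The step that gives a 9.5-fold lower number from compound 2 to compound 4 (0.98 log units; beyond the scatter) changes two places at once and cannot be read. Nothing available accounts for the lower number of compound 4.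

On these data alone, whether the nitrile or simply a short chain matters stays open; a plain ethyl group or a carboxylic acid on that chain would separate the two. Also open, as far as these compounds go, is whether cyanomethyl gives a similar step when methylsulfanyl replaces methyl on the carbon with a double bond to nitrogen.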